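This account rests on a few compounds, and the source may have more. Where it says the series, first, only, none or still open, it means among the compounds named here.

Measured compounds:
compound 1, `CCCCCCCCNC1=CC(=O)C=C(C[C@]2(C)[C@@H](C)CC[C@]3(C)C(C)=CCC[C@@H]23)C1=O`, 38000 nM in a functional assay on NCI-H460 cells (Homo sapiens) for cytotoxicity, read by MTT assay, with a stated time of 72 h; a higher number here means a weaker inhibitor, a lower number a stronger inhibitor
compound 2, `CNC1=CC(=O)C(C(C)(C)C)=CC1=O`, 63000 nM

Compound 1 has the lower of these two numbers in this assay, but its gap to compound 2 lies within the scatter, so the two stand level rather than in any order. Compound 3 is `CCCCNC1=CC(=O)C=C(C[C@]2(C)[C@@H](C)CC[C@]3(C)C(C)=CCC[C@@H]23)C1=O`, and it differs from compound 1 in a single place: hydrogen in place of butyl on a saturated chain carbon, four bonds along the chain from an amine nitrogen. Among the measured compounds shown here, no step between measured compounds is available here, so nothing of the same kind can be leaned on, and compound 2 shares only part of the core with compound 1. On that thin footing, the step is expected to be small, probably a modest move toward a higher number and possibly none beyond the scatter, a 1.3-fold higher number from compound 1 to compound 3 (0.12 log units; within the scatter). Compound 3 is accordingly estimated at 50000 nM, with a range from 20000 nM to 150000 nM.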

Compound 3, half-maximal inhibitory concentration: 16000 nM
Estimate against measurement, compound 3: 3.1-fold (0.49 log units) above; the measured number lies below the stated range.
By their numbers in this assay, from the lowest: compound 3; then compounds 1 and 2 (each within the scatter of the next).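

Among the compounds shown here, removing the outer butyl, with hydrogen in its place on a saturated chain carbon, four bonds along the chain from an amine nitrogen, gives a 2.4-fold lower number from compound 1 to compound 3 (0.38 log units; beyond the scatter) in this assay and is the only step so far that lies beyond the scatter. It shows that the outer part of this chain is not needed for the cytotoxic effect in these cells, and that the longer chain of compound 1 gives no gain at this place. No measured evidence accounts for the size or direction of this step.

For the compounds shown here, with only one step along this chain, it stays open whether a still shorter chain, such as propyl, ethyl or methyl, would continue this move or reverse it. As far as these compounds go, it is also open how a chain ending in a hydroxyl or an amine, or a cyclohexyl ring, would fare here.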